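Shortening the chain on a guanine-like core

The source may report more compounds than this note shows. Statements on the series, on what has been measured and on what is new or still open speak of the compounds shown alone.

Measured compounds:
compound 1, `Nc1nc(O)c2c(n1)n(C1OC(CO)[C@@H](O)[C@H]1O)c(=O)n2C/C=C/c1ccccc1`, 73%
compound 2, `C=CCn1c(=O)n([C@@H]2O[C@H](CO)[C@H]3OC(C)(CCC(=O)NC)O[C@H]32)c2nc(N)nc(O)c21`, 9%
compound 3, `C=CCn1c(=O)n(C2OC(CO[Si](C)(C)C(C)(C)C)[C@@H](O)[C@H]2O)c2nc(N)nc(O)c21`, 5%

Of the compounds shown here, three have been measured in a functional assay on the whole organism (B cells) with Mus musculus as the target; on this read-out lower numbers stand for smaller maximal responses and higher numbers for larger maximal responses. Compound 1 stands highest of the three with 73%. Its nearest neighbour is compound 2, which gives 9%, a gap beyond the scatter. Compound 3, the furthest from it, gives 5%, again beyond the scatter. Compounds 2 and 3 lie within the scatter of each other, so no order between them can be read.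

Compound 4, `Cn1c(=O)n(C2OC(CO)[C@@H](O)[C@H]2O)c2nc(N)nc(O)c21`, has not yet been measured in this assay. It differs from compound 1 in one place: hydrogen in place of 2-phenylethenyl on a saturated chain carbon bound to an aromatic nitrogen. Among the compounds with values here, none of the measured pairs differ in a single place, so no measured step tells directly how this change acts, and compounds 2 and 3 differ from compound 4 both in the chain and elsewhere.

Because compound 1 reaches 73% while compound 2 gives 9% and compound 3 gives 5%, a step in this assay of notable size downward is expected from compound 1 to compound 4, estimated as a number 48 percentage points lower from compound 1 to compound 4 (beyond the scatter). For compound 4 the estimate is 25%, within a range from 5% to 55%.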

Compound 4, largest response reached (reported as maximal response), in percent of the reference or control that the assay uses: 99%
Beside the measured number, compound 4's estimate is 74 percentage points below it; the whole stated range lies below it.
By their numbers in this assay, from the lowest: compounds 3 and 2 (each within the scatter of the next); then compound 1; then compound 4.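

In this assay, exchanging 3-phenylprop-2-en-1-yl for methyl gives a number 26 percentage points higher from compound 1 to compound 4 (beyond the scatter), so a large maximal response at this place on the shared core does not depend on the 2-phenylethenyl group. Within the data shown here, this is the first comparison that differs in one place, and it shows directly that the six-membered aromatic ring and the double bond outside it can leave together, with the small methyl group giving the higher read-out of the pair. The compounds shown offer no independent measurement that explains this rise.

Among these compounds, the single step removes the aromatic ring, the double bond and most of the chain at once, so it remains open which of these changes carries the effect, and compounds 2 and 3 differ from compound 4 in more than one place and cannot settle this. As far as these compounds go, how an ethyl group, a benzyl group or a longer chain ending in an amine would read at this place also remains open, and these would show whether the response changes gradually with chain size or depends on a particular group.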